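Second methoxy on the core of compound 3: compound 4

The compounds below may be only part of what the source reports. "The series", "measured", "known", "first", "only" and "open" are said of these compounds alone.

Measured in an assay on RBL-1 cells for inhibition of Polyunsaturated fatty acid 5-lipoxygenase (Rattus norvegicus); a higher number here means a weaker inhibitor, a lower number a stronger inhibitor:
- compound 1 `O=C(/C=C/c1ccc(O)c(O)c1)c1ccccc1-c1cccnc1`: 210 nM
- compound 2 `O=C(/C=C/c1ccc(O)c(O)c1)c1ccccc1Cl`: 92 nM
- compound 3 `COc1ccccc1C(=O)/C=C/c1ccc(O)c(O)c1`: 27 nM

Compound 3 stands lowest of the three numbers in this assay. Its nearest neighbour is compound 2, the gap being a 3.4-fold lower number from compound 2 to compound 3 (0.53 log units; beyond the scatter); the widest gap is a 7.8-fold lower number from compound 1 to compound 3 (0.89 log units; beyond the scatter). Both are beyond the scatter, so compound 3 is the strongest inhibitor of the three. The third step, a 2.3-fold lower number from compound 1 to compound 2 (0.36 log units; beyond the scatter), is the smallest.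

Compound 4 `COc1cccc(OC)c1C(=O)/C=C/c1ccc(O)c(O)c1` differs from compound 3 by methoxy in place of hydrogen on an aromatic carbon. The measured steps that bear on it are the two that end in compound 3, a 7.8-fold lower number from compound 1 to compound 3 (0.89 log units; beyond the scatter) and a 3.4-fold lower number from compound 2 to compound 3 (0.53 log units; beyond the scatter), since both put a methoxy in place of another group on the same ring. For the measured compounds named here, neither, however, adds a methoxy where a hydrogen sits, and no measured pair shows a second methoxy on this ring; a direct precedent is lacking. A modest step is therefore expected, in either direction, most likely not far beyond the scatter.

For compound 4 the estimate in this assay is 32 nM, with a range from 10 nM to 100 nM. This amounts to an expected step of a 1.2-fold higher number from compound 3 to compound 4 (0.07 log units; within the scatter).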

Compound 4, half-maximal inhibitory concentration: 370 nM
The estimate for compound 4 lay 12-fold (1.06 log units) below the measured number, and the stated range ends below it.
By their numbers in this assay, from the lowest: compound 3; then compound 2; then compounds 1 and 4 (each within the scatter of the next).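

In this assay, methoxy in place of hydrogen, ortho to a large group and meta to a methoxy group, gives a 14-fold higher number from compound 3 to compound 4 (1.14 log units; beyond the scatter), so a second methoxy on this ring weakens inhibition rather than extending the advantage of the single methoxy. The earlier steps shown here only exchanged pyridin-3-yl, chloro and methoxy for one another on the same ring, and the best of those exchanges did not show that a carbon bearing hydrogen could be this sensitive to substitution. This is the largest step in the set, larger than any of those exchanges, which makes the hydrogen at this position a stronger determinant of the number than the choice among the three groups compared earlier. Nothing available on these compounds accounts for the size of the step.

Going by these compounds, whether the weakening belongs to methoxy itself or to any group at this carbon remains open, and a fluorine, a hydroxyl or a methyl there, with the first methoxy kept, would separate the two readings. Also open, on these data alone, is whether a second methoxy on another carbon of this ring would give a step of similar size.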